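The source may report more compounds than this note shows. Statements on the series, on what has been measured and on what is new or still open speak of the compounds shown alone.

In an assay on isolated protein for inhibition of protein deacetylase HDAC6 (Homo sapiens), read by fluorescence, with a stated time of 1 h, tested at 100 nM (a higher number here means more inhibition at the concentration tested (going by the name of the read-out), a lower number less inhibition), compound 1 `O=C(CCc1ccc(OCc2nc(C3CCN(Cc4ccccc4)CC3)no2)cc1)NO` gives 22%. Compound 2 `Cc1ccc(CN2CCC(c3noc(COc4ccc(CCC(=O)NO)cc4)n3)CC2)cc1` carries the change methyl in place of hydrogen on an aromatic carbon and in this assay gives 28%; the step is a number 6 percentage points higher from compound 1 to compound 2 (within the scatter). Compound 3 `CN(Cc1nc(C2CCN(Cc3ccccc3)CC2)no1)c1ncc(C(=O)NO)cn1` is built on a different core, and how its core differs from that of compound 1 is not broken down here. In this assay compound 3 gives 63%, the highest of the three values, with compound 2 and compound 1 both lying beyond the scatter below it.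

Compound 4 `Cc1cccc(CN2CCC(c3noc(CN(C)c4ncc(C(=O)NO)cn4)n3)CC2)c1` has not yet been measured. It differs from compound 3 by methyl in place of hydrogen on an aromatic carbon. For the measured compounds named here, this is the same kind of change as the one from compound 1 to compound 2, but not the same one: there the methyl sits para to a large group, here meta to a large group. Because the earlier step of a number 6 percentage points higher from compound 1 to compound 2 (within the scatter) stayed within the scatter, a step of similar size is expected from compound 3 to compound 4, namely a number 2 percentage points higher from compound 3 to compound 4 (within the scatter). Compound 4 is therefore estimated at 65%, expected to fall between 50% and 78%.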

Compound 4, a percentage reported as inhibition, at one concentration (the size of the read-out at that concentration, not a potency): 54%
Compound 4: middle estimate off by 11 percentage points, on the high side, and the stated range covers the measured number.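

In this assay, placing a methyl on the benzyl ring of compound 3 gives a number 9 percentage points lower from compound 3 to compound 4 (within the scatter), so this step alone shows no real change. Set beside the earlier step, the change does not carry a fixed effect from one core to the other: the same change on two cores in this assay, a number 6 percentage points higher (within the scatter) from compound 1 to compound 2 and a number 9 percentage points lower (within the scatter) from compound 3 to compound 4, 15 percentage points apart, beyond the scatter of two such steps This does not show that either core truly gains or loses activity from the methyl, and it cannot separate the influence of the core from that of the methyl's place on the ring, which is meta to a large group in compound 4 but differs in compound 2.

The compounds shown leave open whether the two cores would still respond differently with the methyl in the same place on the ring. They also leave open how either core would respond to a different group there, such as a chlorine atom, a methoxy group or an amine.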